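The source may report more compounds than this note shows. Statements on the series, on what has been measured and on what is new or still open speak of the compounds shown alone.

Measured compounds:
compound 1, `Cc1ccc(-c2c(CN3CCCCC3)nc3scc(C(=O)O)n23)cc1`, 7630 nM
compound 2, `COc1ccc(-c2c(CN3CCCCC3)nc3scc(C(=O)O)n23)cc1`, 47400 nM
compound 3, `CC(=O)NNC(=O)c1csc2ncc(-c3ccc(C)cc3)n12`, 74200 nM

All three were tested in a functional assay on HeLa cells (Homo sapiens) for antiproliferative activity, read by MTT assay, with a stated time of 72 h; a higher number here means a weaker inhibitor, a lower number a stronger inhibitor. Compound 1 and compound 2 share one core and differ in a single spot: methoxy in place of methyl on an aromatic carbon. That change gave a 6.2-fold higher number from compound 1 to compound 2 (0.79 log units; beyond the scatter), so compound 2 is the weaker inhibitor of the two.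

Compound 3 is built on a different core, and the difference between the two cores is not broken down here. In this assay compound 3 gives a number close to that of compound 2, and the gap between them lies within the usual scatter, so no order can be read from it. Against compound 1, compound 3 gives a clearly higher number, a gap beyond the scatter.

Compound 4, `COc1ccc(-c2cnc3scc(C(=O)NNC(C)=O)n23)cc1`, has not yet been measured. It differs from compound 3 by methoxy in place of methyl on an aromatic carbon, which is the same change already seen between compound 1 and compound 2, at the same kind of place. On that one precedent, compound 4 is expected to give a higher number than compound 3, a step of about a 3.4-fold higher number from compound 3 to compound 4 (0.53 log units; beyond the scatter), roughly the size of the earlier one, because the earlier change gave a 6.2-fold higher number from compound 1 to compound 2 (0.79 log units; beyond the scatter). Since compound 3 already gives 74200 nM, the estimate for compound 4 is 250000 nM, between 70000 nM and 800000 nM.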

Compound 4, half-maximal inhibitory concentration: 17900 nM
For compound 4 the middle estimate is 14-fold (1.15 log units) above the measured one; measured number outside the range, below it.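

In this assay, putting methoxy in place of methyl on the aromatic carbon lowered the number on this second core, a 4.1-fold lower number from compound 3 to compound 4 (0.62 log units; beyond the scatter), which makes the methoxy compound the stronger inhibitor of this pair. Within the data shown here, on the first core the same swap made the compound weaker, so the change ran in opposite directions on the two cores, and the gap between the two steps is too large to be scatter: the same change on two cores in this assay, a 6.2-fold higher number (0.79 log units; beyond the scatter) from compound 1 to compound 2 and a 4.1-fold lower number (0.62 log units; beyond the scatter) from compound 3 to compound 4, 26-fold (1.41 log units) apart, beyond the scatter of two such steps This shows that, in this series, the effect of swapping methyl for methoxy cannot simply be carried from one core to the other, not even in direction; it does not show why the result reverses, and with only one pair on each core it cannot say how either step would hold up in further pairs.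

Still open, as far as these compounds go, is which of the features separating the two cores sets the direction of the step, for instance whether an acetyl hydrazide in place of the carboxylic acid on the core of compound 1 would be enough to reverse it. Also open, from the compounds shown here alone, is how a chlorine or an amine on that same aromatic carbon would behave on each core.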